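A few compounds are considered here, and "the series" means these few. Any claim that something is new, unique, unknown or untested is made for them only; others in the source may bear on it.

Three compounds were measured in a functional assay on CHO cells with adenosine receptor A1 (Homo sapiens) as the target, read by cAMP accumulation and immunoassay, with a stated time of 6 min, tested at 0.1 uM; a higher number here means a weaker effect of the compound at the concentration tested, a lower number a stronger effect:

Compound 1 `CC(C)N1CCN(Cc2csc(N)c2C(=O)c2ccc(Cl)cc2)CC1`: 3.6%
Compound 2 `Nc1scc(CN2CCN(c3ccc(OC(F)(F)F)cc3)CC2)c1C(=O)c1ccc(Cl)cc1`: -13%
Compound 3 `Nc1scc(CN2CCN(C3CCCCCC3)CC2)c1C(=O)c1ccc(Cl)cc1`: 13%

Compound 3 carries the highest of the three numbers. Its gap to compound 1 is small, a number 9.4 percentage points higher from compound 1 to compound 3 (within the scatter), so the two are not separable. Its gap to compound 2 is larger, a number 26 percentage points higher from compound 2 to compound 3 (beyond the scatter), which is beyond the scatter.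

Compound 4 `Nc1scc(CN2CCN(c3ccc(F)cc3F)CC2)c1C(=O)c1ccc(Cl)cc1` differs from compound 3 in one place: 2,4-difluorophenyl in place of cycloheptyl on an amine nitrogen in a ring. Among the measured compounds shown here, the change that bears most directly on it is the one between compound 2 and compound 3, where an aryl group gave way to cycloheptyl and the number rose, a number 26 percentage points higher from compound 2 to compound 3 (beyond the scatter). Compound 4 runs that change in the opposite direction, toward an aryl group on the ring nitrogen. A related step, from isopropyl to an aryl group, also lowered the number, a number 16.6 percentage points lower from compound 1 to compound 2 (beyond the scatter). Both point the same way, so a drop of modest size is expected, a number 21 percentage points lower from compound 3 to compound 4 (beyond the scatter). Compound 4 is therefore estimated at -8% in this assay, with a range from -30% to 14%.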

Compound 4, a percentage reported as activity, at one concentration (the size of the read-out at that concentration, not a potency): -17%
Beside the measured number, compound 4's estimate is 9 percentage points above it; the range from low to high includes it.
By their numbers in this assay, from the lowest: compounds 4 and 2 (each within the scatter of the next); then compounds 1 and 3 (each within the scatter of the next).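

On the amine nitrogen in the ring, 2,4-difluorophenyl cannot be told apart from 4-(trifluoromethoxy)phenyl in this assay, with a number 4 percentage points lower from compound 2 to compound 4 (within the scatter). The aryl-for-alkyl exchange now holds for a second aryl group, against cycloheptyl with a number 30 percentage points lower from compound 3 to compound 4 (beyond the scatter) and against isopropyl with a number 20.6 percentage points lower from compound 1 to compound 4 (beyond the scatter), and none of the four compounds goes against it. No measurement shown here accounts for this grouping.

The compounds shown leave open whether a plain phenyl group, with no fluorine-bearing substituent, would give a number like those of the two aryl compounds. They also leave open whether a benzyl group on that nitrogen would fall with the aryl compounds or with the alkyl ones.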